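A few compounds are considered here, and "the series" means these few. Any claim that something is new, unique, unknown or untested is made for them only; others in the source may bear on it.

Compound 1, `CCNC1=NCCC2(CCCCC2)S1`: 0.72
Compound 2, `CNC1=NCCC2(CCCCC2)S1`: 0.91
Compound 3, `CCc1ccc(NC2=NCCC3(CCCCC3)S2)cc1`: 1.75

All three compounds were measured in a physicochemical assay for lipophilicity, at pH 7.4; a lower number here means a more polar compound, a higher number a more lipophilic compound. The change from compound 2 to compound 1 is methyl in place of hydrogen on a saturated chain carbon bound to an amine nitrogen, and the step it made is a number 0.19 log units lower from compound 2 to compound 1 (within the scatter). Compound 3 gives the highest value of the three; the difference between its core and the core of compound 2 is not broken down here.

Compound 4, `CC(C)c1ccc(NC2=NCCC3(CCCCC3)S2)cc1`, has not yet been measured. It differs from compound 3 by methyl in place of hydrogen on a saturated chain carbon bound to an aromatic carbon and a saturated chain carbon. This is the same kind of change as that from compound 2 to compound 1, but not the same: in the earlier pair the carbon that receives the methyl is bound to an amine nitrogen, whereas in compound 4 it is bound to an aromatic carbon and a saturated chain carbon. Within the data shown here, the step from compound 3 to compound 4 is expected to be a number 0.40 log units higher from compound 3 to compound 4 (beyond the scatter), a modest rise rather than the flat result seen in the earlier pair, and it rests only on the single step of a number 0.19 log units lower from compound 2 to compound 1 (within the scatter) and on the starting value of compound 3. In this assay compound 4 is therefore estimated at 2.15, most likely between 1.75 and 2.55.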

Compound 4, distribution coefficient: 1.45
Compound 4: the middle estimate sits 0.70 log units above what was measured, and the stated range ends above it.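

In this assay the new step reads a number 0.30 log units lower from compound 3 to compound 4 (within the scatter) and the earlier one reads a number 0.19 log units lower from compound 2 to compound 1 (within the scatter) so on both cores methyl in place of hydrogen on a saturated chain carbon gave a step that stays within the scatter. Among these compounds, this does not show that the change carries from one core to another as a fixed amount: there are only two pairs, neither step can be told apart from repeat measurement, and the methyl enters at a different place in each, on a carbon bound to an amine nitrogen in compound 1 and on a carbon bound to an aromatic carbon and a saturated chain carbon in compound 4. No measurement at hand offers an explanation for either step.

The compounds shown leave open whether a longer chain or an amine in place of the methyl would give a step beyond the scatter in this assay on either core. They also leave open how the same methyl change behaves on any further core.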